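Trifluoromethylphenyl in Place of Dichlorophenyl on the Amide Nitrogen

The source may report more compounds than this note shows. Statements on the series, on what has been measured and on what is new or still open speak of the compounds shown alone.

Three compounds share one core and differ only in the aryl group carried by an amide-type nitrogen. Compound 1 `COc1cc(Cl)cc(-c2nn(-c3cccc(NC(=O)Nc4ccc(Cl)c(C(F)(F)F)c4)c3)cc2-c2ccncc2)c1`, compound 2 `COc1cc(Cl)cc(-c2nn(-c3cccc(NC(=O)Nc4cc(C(F)(F)F)cc(C(F)(F)F)c4)c3)cc2-c2ccncc2)c1` and compound 3 `COc1cc(Cl)cc(-c2nn(-c3cccc(NC(=O)Nc4ccc(Cl)c(Cl)c4)c3)cc2-c2ccncc2)c1` were tested in a functional assay on MDA-MB-435 cells (Homo sapiens) for inhibition, read by sulforhodamine B assay, with a stated time of 48 h, tested at 0.1 uM; on this read-out lower numbers stand for a stronger effect and higher numbers for a weaker effect at the one concentration tested. In this assay compound 1 gives 93%, compound 2 gives 98% and compound 3 gives 99%. Compound 3 therefore has the highest of the three numbers, yet its gaps to compound 2 and to compound 1 both lie within the scatter, so the three numbers are indistinguishable. Going by the values given here, the single one-place step among them, a number 6 percentage points higher from compound 1 to compound 3 (within the scatter), likewise stays within the scatter.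

Compound 4 `COc1cc(Cl)cc(-c2nn(-c3cccc(NC(=O)Nc4cccc(C(F)(F)F)c4)c3)cc2-c2ccncc2)c1` remains to be measured. It differs from compound 3 in one place: 3-(trifluoromethyl)phenyl in place of 3,4-dichlorophenyl on an amide-type nitrogen. The measured step from compound 1 to compound 3 bears on this change, since it exchanged a trifluoromethyl for a chloro; compound 4 walks the other way and drops the second chloro too. Because a number 6 percentage points higher from compound 1 to compound 3 (within the scatter) stayed within the scatter, the expected step from compound 3 to compound 4 is a number 6 percentage points lower from compound 3 to compound 4 (within the scatter), nothing beyond the scatter. For compound 4 the estimate in this assay is 93%, with a range from 80% to 105%.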

Compound 4, a percentage reported as activity, at one concentration (the size of the read-out at that concentration, not a potency): 97%
The estimate for compound 4 lay 4 percentage points below the measured number; measured number inside the range.
By their numbers in this assay, from the lowest: compounds 1, 4, 2 and 3 (each within the scatter of the next).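

In this assay, 3-(trifluoromethyl)phenyl in place of 3,4-dichlorophenyl on the amide-type nitrogen gives a number 2 percentage points lower from compound 3 to compound 4 (within the scatter), so a whole-group exchange on this ring, with a different count of heavy atoms, leaves the read-out indistinguishable. Taking a single group off the ring reads the same way: hydrogen in place of one trifluoromethyl gives a number 1 percentage points lower from compound 2 to compound 4 (within the scatter), and hydrogen in place of the chloro gives a number 4 percentage points higher from compound 1 to compound 4 (within the scatter), so at this one concentration the extra group on the ring of compound 1 or compound 2 makes no difference that can be told from the scatter. Nothing measured alongside these numbers offers an explanation for them.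

The compounds shown leave open whether a different kind of group at this place, such as an amine or a carboxylic acid on the ring, or a butyl chain instead of the ring, would move the number beyond the scatter. They also leave open whether these four aryl groups would separate from one another at a higher concentration.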